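Aryl swap at the core: furan-2-yl to 2-chloropyridin-4-yl

The source may hold more compounds than are shown below. What is called first, only, known or untested is meant among the compounds shown, and "the series" means these compounds.

Compound 1 `O=C(O)Cc1sc(C(c2ccc(F)cc2)c2ccc(F)cc2)nc1-c1ccco1` reaches 80% in an in vitro functional assay on HEK285-7 cells for antagonist activity at prostaglandin D2 receptor 2 (Homo sapiens), read by BRET and beta-arrestin recruitment; a lower number here means a smaller maximal response, a higher number a larger maximal response. For the measured compounds named here, compound 2 `O=C(O)Cc1sc(C(c2ccccc2)c2ccccc2)nc1-c1ccc(C(F)(F)F)cc1` gives 80% and compound 3 `O=C(O)Cc1sc(C(c2ccccc2)c2ccccc2)nc1-c1ccc(F)c(F)c1` gives 80% in this assay, so compound 1 stands level with both, and the step of no change at the digits printed from compound 2 to compound 3 (within the scatter) is the only single-point change measured so far; it exchanged one six-membered aromatic group for another on the same aromatic carbon of the shared core without moving the maximal response.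

Compound 4 `O=C(O)Cc1sc(C(c2ccc(F)cc2)c2ccc(F)cc2)nc1-c1ccnc(Cl)c1` differs from compound 1 by 2-chloropyridin-4-yl in place of furan-2-yl on an aromatic carbon, a change at the ring atom next to the ring nitrogen and next to the ring atom that bears the carboxymethyl group. The step from compound 2 to compound 3 bears directly on this, and it was flat, so no change beyond the scatter is expected from compound 1 to compound 4 in this assay, giving an expected step of no change at the digits printed from compound 1 to compound 4 (within the scatter). Compound 4 is therefore estimated to reach 80%, with a range of 65% to 95%.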

Compound 4, largest response reached (reported as efficacy), in percent of the reference or control that the assay uses: 80%
The estimate for compound 4 equals the measured number at the digits printed; low and high end bracket the measured number.
By their numbers in this assay, from the lowest: compounds 1, 2, 3 and 4 (each within the scatter of the next).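

The exchange of furan-2-yl for 2-chloropyridin-4-yl gives no change at the digits printed from compound 1 to compound 4 (within the scatter) in this assay. Unlike the earlier step, which swapped one six-membered aromatic group for another, this one replaces a five-membered aromatic ring with a six-membered aromatic ring, raises the substituent from 5 to 7 heavy atoms and brings in a chlorine, all on the same aromatic carbon, and the maximal response stays level. No measurement at hand accounts for this flat result.

All four compounds carry an aromatic ring on this carbon and all stand level, so the compounds shown cannot tell whether the maximal response depends on the group here at all. On these data alone, how an amine, a morpholine or a longer alkyl chain on this carbon would read remains open.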